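Removing one fluoro from compound 2

The source may report more compounds than this note shows. Statements on the series, on what has been measured and on what is new or still open speak of the compounds shown alone.

Values in a functional assay on MKN-45 cells (Homo sapiens) for antiproliferative activity, read by MTT assay, with a stated time of 72 h (on this read-out lower numbers stand for stronger inhibition and higher numbers for weaker inhibition), for three compounds:
Compound 1 `O=c1c(-c2ccc(F)cc2)c[nH]c2ccnc(Nc3ccc(Oc4ccnc5cc(OCCO)ccc45)c(F)c3)c12` gives 4700 nM
Compound 2 `CC(C)(O)COc1ccc2c(Oc3ccc(Nc4nccc5[nH]cc(-c6ccc(F)cc6)c(=O)c45)cc3F)ccnc2c1` gives 2700 nM
Compound 3 `O=c1c(-c2ccc(F)cc2)c[nH]c2ccnc(Nc3ccc(Oc4ccnc5cc(O)ccc45)c(F)c3)c12` gives 5000 nM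

Compound 2 sits level with the other two: the gaps are a 1.7-fold lower number from compound 1 to compound 2 (0.24 log units; within the scatter) and a 1.9-fold higher number from compound 2 to compound 3 (0.27 log units; within the scatter) and neither separates them. Compound 4 `CC(C)(O)COc1ccc2c(Oc3ccc(Nc4nccc5[nH]cc(-c6ccccc6)c(=O)c45)cc3F)ccnc2c1` keeps everything in compound 2 but one change: hydrogen in place of fluoro on an aromatic carbon. In words, this is hydrogen in place of fluoro on an aromatic carbon, so 4-fluorophenyl becomes phenyl.

Among the compounds with values here, no measured step touches this spot. All three compounds carry the 4-fluorophenyl group, and their steps, including a 1.1-fold higher number from compound 1 to compound 3 (0.03 log units; within the scatter) and the two above, alter only the group on an oxygen. They bear on the new change only indirectly, so no direction can be favoured, and in this assay no step beyond the scatter is expected. The starting point is compound 2 at 2700 nM in this comparison. The estimated change is a 1.1-fold higher number from compound 2 to compound 4 (0.05 log units; within the scatter) and nothing larger is expected. For compound 4 the expected value is 3000 nM with an estimated range from 1300 nM to 7000 nM on this read-out.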

Compound 4, half-maximal inhibitory concentration: 2900 nM
For compound 4 the middle estimate is 1.0-fold (0.01 log units) above the measured one; the measured number falls inside the stated range.
By their numbers in this assay, from the lowest: compounds 2, 4, 1 and 3 (each within the scatter of the next).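

Within the data shown here, compounds 1, 2 and 3 all carry the 4-fluorophenyl group, so this pair is the first to test that spot. In this assay the change from 4-fluorophenyl to phenyl gives a 1.1-fold higher number from compound 2 to compound 4 (0.03 log units; within the scatter) and cannot be told apart from the usual scatter. With the 2-hydroxy-2-methylpropyl group on the oxygen, then, the fluoro para to a large group can give way to hydrogen without a readable change in this assay, and no measurement shown offers an explanation for that result.

Still open, as far as these compounds go, is whether a larger group at this spot, such as methoxy, an amine or a carboxylic acid, would shift the number beyond the scatter. Also open, from the compounds shown here alone, is whether the exchange of fluoro for hydrogen would read the same with the 2-hydroxyethyl group of compound 1 on the oxygen.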